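The source may report more compounds than this note shows. Statements on the series, on what has been measured and on what is new or still open speak of the compounds shown alone.

Compound 3 `CC(C)(C)c1ccc(C(=O)N/N=C/c2cc(O)cc(O)c2)cc1` gives 10.9% in a physicochemical assay, read by spectrophotometry, with a stated time of 60 min, tested at 100 uM; a higher number here means a stronger effect of the compound at the concentration tested, a lower number a weaker effect. Within the data shown here, on the three numbers so far it stands second highest: nearest is compound 2 `COc1ccc(/C=C/C=N/NC(=O)c2ccc(C(C)(C)C)cc2)cc1` with 8.3%, within the scatter; furthest is compound 1 `COc1cc(/C=C/C=N/NC(=O)c2ccc(C(C)(C)C)cc2)ccc1O` with 45.6%, beyond the scatter. Compound 4 `O=C(N/N=C/c1cc(O)cc(O)c1)c1ccc(O)cc1` has not been measured in this assay; from compound 3 it differs by hydroxy in place of tert-butyl on an aromatic carbon. Among the measured compounds shown here, no step between measured compounds is available to size this change. Since compound 1, which also carries a hydroxy, gives 45.6%, a higher number than compound 3, a rise of moderate size in this assay is expected for compound 4 rather than none. The estimate for compound 4 is 30% (range 12% to 55%). The expected step is a number 19.1 percentage points higher from compound 3 to compound 4 (beyond the scatter).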

Compound 4, a percentage reported as inhibition, at one concentration (the size of the read-out at that concentration, not a potency): 11.2%
Compound 4: middle estimate off by 18.8 percentage points, on the high side; the measured number lies below the stated range.
By their numbers in this assay, from the lowest: compounds 2, 3 and 4 (each within the scatter of the next); then compound 1.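

On the aromatic carbon para to a large group, with the rest of compound 3 held, hydroxy in place of tert-butyl gives a number 0.3 percentage points higher from compound 3 to compound 4 (within the scatter) in this assay. Losing the four carbons of tert-butyl and adding a hydrogen-bond donor and acceptor therefore leaves no readable change at this position. Nothing available explains this outcome.

Going by these compounds, whether an amine or a carboxylic acid at this position would also leave the read-out in place remains open. So does whether this exchange gives a similar step on the core of compound 1.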